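A few compounds are considered here, and "the series" means these few. Any claim that something is new, unique, unknown or untested is made for them only; others in the source may bear on it.

Measured so far in a functional assay on the whole organism (strain albino) for inhibition, with Rattus norvegicus as the target, read by paw edema, with stated times of 1 h and 2 h, at a dose of 20 mmol/kg by the intraperitoneal route; a higher number here means more inhibition at the dose given (going by the name of the read-out), a lower number less inhibition:
- compound 1 `N#CC1=C(NCC(=O)N2CCCC2)N(c2ccccc2)C(=O)N2CCCCC(N3CCCC3)C12`: 49.8%
- compound 2 `N#CC1=C(NCN2CCCCC2)N(c2ccccc2)C(=O)N2CCCCC(N3CCCC3)C12`: 36.9%

Compound 2 stands lowest of the two numbers in this assay; its nearest neighbour, compound 1, lies higher by a number 12.9 percentage points lower from compound 1 to compound 2 (beyond the scatter), a step beyond the scatter, made by piperidin-1-yl in place of (pyrrolidin-1-yl)carbonyl on a saturated chain carbon bound to an amine nitrogen.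

Compound 3 `N#CC1=C(/N=C/c2ccc([N+](=O)[O-])cc2)N(c2ccccc2)C(=O)N2CCCCC(N3CCCC3)C12` has not been measured. It differs from compound 2 by a group of 11 heavy atoms (7 carbon, 2 nitrogen, 2 oxygen; one six-membered aromatic ring of carbon only) in place of a group of 8 heavy atoms (6 carbon, 2 nitrogen; one six-membered non-aromatic ring with 1 hetero atom), on a double-bonded ring carbon. The new group has no common name and is set on a double-bonded ring carbon of the shared core.

Within the data shown here, no measured step bears on this change. Among the measured compounds shown here, the single known step, from compound 1 to compound 2, exchanges groups on a saturated chain carbon and leaves the amine nitrogen in place, whereas the step to compound 3 removes the hydrogen-bond donor and brings in a six-membered aromatic ring with a nitro group. The direction of this assay cannot be read from the two numbers shown, so the expected step is a number 3.1 percentage points higher from compound 2 to compound 3 (within the scatter), with a wide range. Compound 3 is estimated at 40% in this assay, between 20% and 60%.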

Compound 3, a percentage reported as inhibition, in the whole organism at one dose (the size of the read-out at that dose, not a potency): 80.9%
Estimate against measurement, compound 3: 40.9 percentage points below; the whole stated range lies below it.
By their numbers in this assay, from the lowest: compound 2; then compound 1; then compound 3.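

In this assay, the group on the double-bonded ring carbon proves a far stronger lever than the chain carbon varied earlier: replacing ((piperidin-1-yl)methyl)amino gives a number 44 percentage points higher from compound 2 to compound 3 (beyond the scatter), against only a number 12.9 percentage points lower from compound 1 to compound 2 (beyond the scatter) for the earlier exchange. The same position also separates compound 3 from the amide-bearing side chain, with a number 31.1 percentage points higher from compound 1 to compound 3 (beyond the scatter), so compound 3 stands highest of the three, with both of its steps beyond the scatter. This position therefore accepts a group with a six-membered aromatic ring of carbon only and no hydrogen-bond donor, with a higher number than either side chain carrying a donor; nothing measured here explains that rise.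

The change alters the ring, the nitro group, the linking atoms and the hydrogen-bond donor count together, so the share of each in the rise stays unresolved. Open as well is whether the number holds with a methoxy group or a chlorine in place of the nitro group, or with a bare phenyl on the same link.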